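A few compounds are considered here, and "the series" means these few. Any claim that something is new, unique, unknown or untested is made for them only; others in the source may bear on it.

Compound 2 `O=C1C(O)=C(C(c2ccc(Cl)cc2)c2c[nH]c3ccccc23)C(=O)c2ccccc21` shows the lower of the two numbers in a toxicity assay (Homo sapiens) for cytotoxicity, read by MTT assay, with a stated time of 48 h (a lower number here means a stronger inhibitor, a higher number a weaker inhibitor), giving 102000 nM. Compound 1 `COc1cccc(C(C2=C(O)C(=O)c3ccccc3C2=O)c2c[nH]c3ccccc23)c1` gives 110000 nM, and the step of a 1.1-fold lower number from compound 1 to compound 2 (0.03 log units; within the scatter) lies within the scatter, so no order between the two can be claimed. Compound 3 `O=C1C(O)=C(C(c2cccs2)c2c[nH]c3ccccc23)C(=O)c2ccccc21` differs from compound 2 by thiophen-2-yl in place of 4-chlorophenyl on a saturated chain carbon bound to an aromatic carbon and a double-bonded ring carbon. Among the compounds with values here, the only measured step that bears on this change is the earlier exchange of one aryl group for another on the same saturated chain carbon, which stayed within the scatter. No step beyond the scatter is therefore expected in this assay. For compound 3 the expected value in this assay is 100000 nM, with a range from 50000 nM to 200000 nM. The step this estimate implies is a 1.0-fold lower number from compound 2 to compound 3 (0.01 log units; within the scatter), expected to remain within the scatter.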

Compound 3, half-maximal inhibitory concentration: 31300 nM
Estimate against measurement, compound 3: 3.2-fold (0.50 log units) above; measured number outside the range, below it.
By their numbers in this assay, from the lowest: compound 3; then compounds 2 and 1 (each within the scatter of the next).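

In this assay the saturated chain carbon bound to an aromatic carbon and a double-bonded ring carbon proves sensitive to the group it carries, which the exchange of 4-chlorophenyl and 3-methoxyphenyl did not reveal. Thiophen-2-yl gives a 3.3-fold lower number from compound 2 to compound 3 (0.51 log units; beyond the scatter) and a 3.5-fold lower number from compound 1 to compound 3 (0.55 log units; beyond the scatter), both modest. No supporting data account for this shift.

Still open, as far as these compounds go, is whether the shift follows the five-membered ring or its sulfur, which furan-2-yl or unsubstituted phenyl at this position would help separate.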